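The compounds below may be only part of what the source reports. "The series", "measured", "known", "first", "only" and "open" are said of these compounds alone.

Measured so far:
- Compound 1, `O=C(CN1CCN(c2nnc(Cc3ccccc3)c3ccccc23)CC1)Nc1c(F)cccc1F`: 84500 nM in a functional assay on A549 cells (Homo sapiens) for cytotoxicity, read by MTT assay, with a stated time of 72 h; on this read-out lower numbers stand for stronger inhibition and higher numbers for weaker inhibition
- Compound 2, `COc1ccc(NC(=O)CN2CCN(c3nnc(Cc4ccccc4)c4ccccc34)CC2)cc1OC`: "not active" (no number reported) in this assay

Both compounds share the same core and differ only in the aromatic group attached to the amide-type nitrogen. In this assay compound 1 gives 84500 nM, a weak result on this read-out. Among the compounds with values here, for compound 2 the outcome in this assay is simply "not active" (no number reported): no number is reported, so compound 2 has no place on a numerical scale here, and no measured step can be drawn from it.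

Compound 3, `O=C(CN1CCN(c2nnc(Cc3ccccc3)c3ccccc23)CC1)Nc1ccc(F)c(F)c1`, is the next compound to be tested. Its difference from compound 2 is 3,4-difluorophenyl in place of 3,4-dimethoxyphenyl on an amide-type nitrogen. With compound 2 giving no number, the size and direction of this step in this assay cannot be read from a measured pair; the best guide is compound 1, which also carries a fluorinated aromatic ring on the amide-type nitrogen and gives 84500 nM. Compound 3 is therefore expected to be weakly active at best, with a real chance of again returning no number. For compound 3 the estimated value in this assay is 90000 nM, expected to lie between 30000 nM and 300000 nM.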

Compound 3, half-maximal inhibitory concentration: 10100 nM
Beside the measured number, compound 3's estimate is 8.9-fold (0.95 log units) above it; measured number below the stated range.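

In this assay, the swap of 2,6-difluorophenyl for 3,4-difluorophenyl on the amide-type nitrogen gives an 8.4-fold lower number from compound 1 to compound 3 (0.92 log units; beyond the scatter), and since a lower number stands for stronger inhibition, this position responds to where the two fluorines sit on the ring, not merely to their presence. Compound 3 gives 10100 nM while compound 2, with 3,4-dimethoxyphenyl at the same place, is reported only as "not active", so the size of the step between these two cannot be read, although the difference in outcome shows that the choice of ring substituents matters here. Nothing measured here accounts for these differences, so the reason behind them remains unknown.

The compounds shown leave open how a plain phenyl ring, with no substituents at all, or a chlorophenyl group would compare with the 3,4-difluorophenyl group of compound 3 at this place. They also leave open whether the aromatic ring is needed at all, as a cyclohexyl group on the same nitrogen would show.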